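Ring Reshuffle at the Amide Nitrogen, Still at the Limit

A few compounds are considered here, and "the series" means these few. Any claim that something is new, unique, unknown or untested is made for them only; others in the source may bear on it.

Three compounds were tested in an assay on isolated protein for inhibition of vitamin D3 receptor (Homo sapiens), read by fluorescence polarization; a higher number here means a weaker inhibitor, a lower number a stronger inhibitor. Compound 1 `CS(=O)(=O)c1ccc(C(=O)N2CCC(C(=O)N(Cc3ccccc3)Cc3ccccc3)CC2)cc1[N+](=O)[O-]` gives > 60000 nM, which is a limit of the assay rather than a number. Compound 2 `CS(=O)(=O)c1ccc(C(=O)N2CCC(C(=O)N3CCc4ccccc4C3)CC2)cc1[N+](=O)[O-]` likewise returns > 60000 nM, again only a limit. Compound 3 `CC(C)N(C(=O)CNC(=O)c1ccc(S(C)(=O)=O)c([N+](=O)[O-])c1)C(C)C` gives > 60000 nM, a limit as well. Compound 2 therefore stands exactly where the whole measured set stands: the limit of > 60000 nM in this assay, at which 3 of the 3 values shown sit. For the measured compounds named here, no pair of measured compounds differs in a single place, so no measured step can be followed, and nothing in these numbers separates one compound from another.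

Compound 4 `CC1Cc2ccccc2N1C(=O)C1CCN(C(=O)c2ccc(S(C)(=O)=O)c([N+](=O)[O-])c2)CC1` has not yet been measured. It differs from compound 2 by 2-methyl-2,3-dihydro-1H-indol-1-yl in place of 1,2,3,4-tetrahydroisoquinolin-2-yl on a carbonyl carbon. The change keeps every atom and only rejoins them: 2-methyl-2,3-dihydro-1H-indol-1-yl replaces 1,2,3,4-tetrahydroisoquinolin-2-yl on the carbonyl carbon whose other neighbour is a saturated ring carbon.

With every measured value sitting at the limit, the step from compound 2 to compound 4 is expected to be a step that the limit leaves unreadable from compound 2 to compound 4, nothing beyond the scatter. Compound 4 is estimated at 80000 nM, within 30000 nM to 300000 nM, and most likely reported again only as a limit.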

Compound 4, half-maximal inhibitory concentration: > 60000 nM
Compound 4 gave a limit, no number (the forecaster's own chance of this, stated with the estimate: 85%); the middle value is on the limit's open side.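

No step from compound 2 to compound 4 can be read in this assay, as both results are limits and not numbers: the limit of > 60000 nM in this assay, at which 4 of the 4 values shown sit.

The compounds shown leave open how strongly any of them inhibits, and whether 2-methyl-2,3-dihydro-1H-indol-1-yl and 1,2,3,4-tetrahydroisoquinolin-2-yl differ at all.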